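A few compounds are considered here, and "the series" means these few. Any claim that something is new, unique, unknown or untested is made for them only; others in the source may bear on it.

Measured compounds in a functional assay on SW480 cells (Homo sapiens) for cytotoxicity, read by MTT assay, with a stated time of 48 h; on this read-out lower numbers stand for stronger inhibition and higher numbers for weaker inhibition:
- compound 1 `Cc1cccc(Cn2cc(COc3ccc4c(=O)ccoc4c3)nn2)c1`: 11700 nM
- compound 3 `O=c1ccoc2cc(OCc3cn(Cc4ccccc4F)nn3)ccc12`: 11400 nM
- compound 2 `O=c1ccoc2cc(OCc3cn(Cc4cccc(Br)c4)nn3)ccc12`: its reading of > 100000 nM is a limit of the assay, not a number.

Compound 2 thus sits at the limit of > 100000 nM in this assay, at which 1 of the 3 values shown sits, the weakest point of the three. Going by the values given here, the only steps that touch it are an at least 8.5-fold higher number from compound 1 to compound 2 (0.93 log units; beyond the scatter) and an at least 8.7-fold lower number from compound 2 to compound 3 (0.94 log units; beyond the scatter), both beyond the scatter and both pointing to the bromo-bearing compound 2 as the outlier, while compound 1 and compound 3 agree within the scatter.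

Compound 4 `N#Cc1cccc(Cn2cc(COc3ccc4c(=O)ccoc4c3)nn2)c1` differs from compound 2 by cyano in place of bromo on an aromatic carbon. Among the compounds with values here, no measured step exchanges bromo for cyano, so the expectation rests on the two steps above: removing bromo has twice moved the number down. A lowering step an at least 3.3-fold lower number from compound 2 to compound 4 (0.52 log units; beyond the scatter) is therefore expected, though smaller and less certain than those. The estimate for compound 4 is 30000 nM (range 9000 nM to 100000 nM).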

Compound 4, half-maximal inhibitory concentration: > 100000 nM
Compound 4 gave a limit, no number; the forecaster's own chance of this, stated with the estimate: 35%; middle value at least 3.3-fold (0.52 log units) from the limit.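

In this assay, compound 4 gives a limit, not a number, as compound 2 does: the limit of > 100000 nM in this assay, at which 2 of the 4 values shown sit.

Cyano at this place therefore behaves like bromo and unlike methyl, with an at least 8.5-fold higher number from compound 1 to compound 4 (0.93 log units; beyond the scatter) and, against the 2-fluorophenyl compound, an at least 8.7-fold higher number from compound 3 to compound 4 (0.94 log units; beyond the scatter). The step between compound 2 and compound 4 cannot be read, so bromo and cyano cannot be ordered.

Open, on these data alone, is whether any other group here, such as an amine, a methoxy group or a carboxylic acid, keeps a readable number. Also open, as far as these compounds go, is how far compound 2 and compound 4 lie past the limit.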